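Amide substituent and maximal response in the shared core

The compounds below may be only part of what the source reports. "The series", "measured", "known", "first", "only" and "open" are said of these compounds alone.

Measured compounds:
compound 1, `C[C@@H]1C[C@@H]1C(=O)N1CC2CNCC2C1`: 180%
compound 2, `C[C@@H]1C[C@H]1C(=O)N1CC2CNCC2C1`: 110%
compound 3, `CC(=O)N1CC2CNCC2C1`: 36%

In an assay on CHO cells for agonist activity at Neuronal acetylcholine receptor; alpha3/beta4 (Homo sapiens), read by FLIPR and calcium flux (a lower number here means a smaller maximal response, a higher number a larger maximal response), compound 1 stands highest of the three measured numbers. The nearest is compound 2, reached by a number 70 percentage points lower from compound 1 to compound 2 (beyond the scatter), and the furthest is compound 3, reached by a number 144 percentage points lower from compound 1 to compound 3 (beyond the scatter). The two compounds with a ring on the carbonyl carbon are separated only by the fact that one of compounds 1 and 2 is drawn with a defined configuration and the other without, at the place where they differ, and that difference alone carries the step between them. The drop from compound 2 to compound 3 is also large, a number 74 percentage points lower from compound 2 to compound 3 (beyond the scatter), so both replacements of the ring-bearing group by methyl on the carbonyl carbon cut the maximal response sharply.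

For the measured compounds named here, compound 4, `CCC(=O)N1CC2CNCC2C1`, is not yet measured. a group of 2 heavy atoms (2 carbon; no ring) in place of a group of 4 heavy atoms (4 carbon; one three-membered non-aromatic ring of carbon only), on a carbonyl carbon The steps that bear on this change are the two that exchange the ring-bearing group for methyl on the carbonyl carbon, and both were large drops. Ethyl is a chain of two carbons rather than a single one, so a drop somewhat smaller than the step to compound 3 is expected, still large: a number 120 percentage points lower from compound 1 to compound 4 (beyond the scatter) is expected. For compound 4 the estimated value in this assay is 60%, with a range from 30% to 110%.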

Compound 4, largest response reached (Emax), in percent of the reference or control that the assay uses: 130%
Beside the measured number, compound 4's estimate is 70 percentage points below it; the whole stated range lies below it.
By their numbers in this assay, from the lowest: compound 3; then compound 2; then compound 4; then compound 1.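

In this assay a ring on the carbonyl carbon is not required for a high maximal response: methyl in place of hydrogen on the saturated chain carbon bound to the carbonyl carbon gives a number 94 percentage points higher from compound 3 to compound 4 (beyond the scatter) and so accounts for a large rise without any ring. Ethyl also stands above one of the two ring-bearing amides, with a number 20 percentage points higher from compound 2 to compound 4 (beyond the scatter) as the step, so compound 2 goes against any reading that the ring-bearing group outperforms the open chain or that the response follows the heavy-atom count of the group. Only the other configuration stays ahead of ethyl, with a number 50 percentage points lower from compound 1 to compound 4 (beyond the scatter) as the step, which makes the ranking of ethyl against the ring-bearing group depend on which of compounds 1 and 2 is taken.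

The compounds shown leave open whether a longer chain such as propyl, a branched isopropyl or an unsubstituted cyclopropyl on the carbonyl carbon would carry the response further up or bring it back down. Nothing shown gives a reason for the ethyl result.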